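The source may hold more compounds than are shown below. What is called first, only, known or untested is meant among the compounds shown, and "the series" means these compounds.

In a functional assay on the whole organism (Abdomen, strain Swiss) for inhibition, with Mus musculus as the target, with stated times of 30 min, 10 min and 5 min, at a dose of 40 mg/kg by the oral route (a higher number here means a stronger effect of the compound at the dose given, a lower number a weaker effect), compound 1 `CCCC(=O)c1c(C)nn(CCCN2CCN(c3ccc(C)cc3)CC2)c(=O)c1N` gives 32%, and compound 2 `CCCCC(=O)c1c(C)nn(CCCN2CCN(c3ccc(C)cc3)CC2)c(=O)c1N` gives 15%. The change between them, (methyl in place of hydrogen on a saturated chain carbon, three bonds along the chain from a carbonyl carbon), made a step of a number 17 percentage points lower from compound 1 to compound 2 (beyond the scatter). Compound 3 `C=Cc1c(CCC)nn(CCCN2CCN(c3ccc(C)cc3)CC2)c(=O)c1N` has a different core; how its core differs from that of compound 1 is not broken down here. In this assay compound 3 gives 22%. Compound 4 `C=Cc1c(CCCC)nn(CCCN2CCN(c3ccc(C)cc3)CC2)c(=O)c1N` differs from compound 3 by methyl in place of hydrogen on a saturated chain carbon, three bonds along the chain from an aromatic carbon. Going by the values given here, this is the same kind of change as the one from compound 1 to compound 2, though the place is not the same: there the carbon sits three bonds along the chain from a carbonyl carbon, here three bonds along the chain from an aromatic carbon. Because the earlier step was a number 17 percentage points lower from compound 1 to compound 2 (beyond the scatter), a step of a number 12 percentage points lower from compound 3 to compound 4 (beyond the scatter) is expected, on a different core. Compound 4 is estimated at 10% in this assay.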

Compound 4, a percentage reported as inhibition, in the whole organism at one dose (the size of the read-out at that dose, not a potency): 48%
Estimate against measurement, compound 4: 38 percentage points below; measured number outside the range, above it.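

In this assay, adding this methyl gives a number 26 percentage points higher from compound 3 to compound 4 (beyond the scatter), so the change cannot be carried from one core to the other as a fixed step. Its direction reverses between the two cores: the same change on two cores in this assay, a number 17 percentage points lower (beyond the scatter) from compound 1 to compound 2 and a number 26 percentage points higher (beyond the scatter) from compound 3 to compound 4, 43 percentage points apart, beyond the scatter of two such steps This does not show what causes the reversal, since the two steps differ both in the core and in the group the chain is attached to, and each rests on a single pair of compounds.

The compounds shown leave open whether a longer chain, such as pentyl, would continue the rise seen on the core of compound 3. They also leave open how the same pentyl chain would behave on the core of compound 1.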